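The source may hold more compounds than are shown below. What is called first, only, known or untested is meant among the compounds shown, and "the series" means these compounds.

Measured so far in a functional assay on the whole organism for inhibition, with Nicotiana tabacum as the target; on this read-out higher numbers stand for weaker inhibition and lower numbers for stronger inhibition: compound 1 `Cc1nc(Nc2ccccc2)c2cc[nH]c2n1` gives 550000000 nM; compound 2 `Cc1nc(Nc2ccc(Cl)cc2)c2cc[nH]c2n1` gives 224000000 nM; compound 3 `Cc1nc(Nc2ccc(C(F)(F)F)cc2)c2cc[nH]c2n1` gives 70800000 nM.

Compound 3 thus holds the lowest number, the strongest inhibition of the three, and its steps to compound 2 and compound 1 are both beyond the scatter. Compound 4 `Cc1nc(Nc2ccc(C#N)cc2)c2cc[nH]c2n1` carries cyano in place of trifluoromethyl on an aromatic carbon. For the measured compounds named here, the steps that bear on this are a 7.8-fold lower number from compound 1 to compound 3 (0.89 log units; beyond the scatter) and a 3.2-fold lower number from compound 2 to compound 3 (0.50 log units; beyond the scatter), both showing that the trifluoromethyl group lowered the number, while a 2.5-fold lower number from compound 1 to compound 2 (0.39 log units; beyond the scatter) was smaller. Going by the values given here, no measured compound carries cyano, so its own effect is unknown; swapping away the trifluoromethyl group may give back part of that gain. Compound 4 is therefore expected to come in near 100000000 nM, between 30000000 nM and 400000000 nM. The expected step of a 1.4-fold higher number from compound 3 to compound 4 (0.15 log units; within the scatter) is estimated to stay within the scatter.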

Compound 4, half-maximal inhibitory concentration: 501000000 nM
The estimate for compound 4 lay 5.0-fold (0.70 log units) below the measured number, and the stated range ends below it.
By their numbers in this assay, from the lowest: compound 3; then compound 2; then compounds 4 and 1 (each within the scatter of the next).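

At this position on the aromatic ring, cyano brings no clear gain over plain hydrogen: a 1.1-fold lower number from compound 1 to compound 4 (0.04 log units; within the scatter) stays within the scatter. It also gives weaker inhibition than the other two substituents, with a 7.1-fold higher number from compound 3 to compound 4 (0.85 log units; beyond the scatter) and a 2.2-fold higher number from compound 2 to compound 4 (0.35 log units; beyond the scatter), so the lower numbers seen with chloro and trifluoromethyl do not extend to every replacement of hydrogen here. Nothing available explains why these groups differ. As far as these compounds go, whether a methoxy group, an amine or a carboxylic acid at this position would lower the number remains open, as does whether trifluoromethyl would keep its effect elsewhere on the ring.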